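The source may hold more compounds than are shown below. What is called first, only, known or untested is meant among the compounds shown, and "the series" means these compounds.

Measured compounds in an ADME assay on Jejunum (Mus musculus, strain C57BL/6) for metabolic stability, read by HPLC, with a stated time of 12 h; on this read-out higher numbers stand for a longer-lived compound and lower numbers for a shorter-lived compound:
- compound 1 `O=C(O)[C@@H](CO)NC(=O)[C@H]1C[C@@H](O)CN1`: > 12 h (a limit of the assay)
- compound 2 `O=C(N[C@H](CO)C(=O)O)[C@@H]1C[C@H](O)CN1`: > 12 h (a limit of the assay)
- compound 3 `O=C(O)[C@H](CO)NC(=O)[C@@H]1C[C@H](O)CN1`: 0.35 h

Among the measured compounds shown here, compound 3, at 0.35 h, holds the only actual number. The other two values are limits. Its neighbour, compound 4 `O=C(O)[C@H](CO)NC(=O)[C@@H]1C[C@@H](O)CN1`, has not yet been measured in this assay. The change is the two compounds have the same atoms and bonds and differ only in configuration as drawn: 1 of 3 stereo elements differ; a stereocentre at a saturated ring carbon is drawn S in compound 3 and R in compound 4, so the saturated chain carbon stays as drawn in compound 3.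

For the measured compounds named here, three measured steps bear on this. The closest, an at least 34-fold lower number from compound 2 to compound 3 (1.53 log units; beyond the scatter), inverts only the chain stereocentre, and an at least 34-fold lower number from compound 1 to compound 3 (1.53 log units; beyond the scatter) inverts all three. Both are large, and both rest on (the limit of > 12 h in this assay, at which 2 of the 3 values shown sit). The third, a step that the two limits leave unreadable from compound 1 to compound 2, inverts both ring stereocentres together, so it gives no size for a single ring inversion. Compound 4 keeps the chain configuration of compound 3, which gives 0.35 h, so it is expected to remain short-lived. From the compounds shown here alone, the expected change is a 1.7-fold higher number from compound 3 to compound 4 (0.23 log units; within the scatter), which is not expected to go beyond the scatter, although the ring inversion remains untested on its own. For compound 4 the estimate is 0.6 h, with an expected range from 0.15 h to 3 h.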

Compound 4, half-life: 0.29 h
Compound 4: the middle estimate sits 2.1-fold (0.32 log units) above what was measured; the range from low to high includes it.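

In this assay, among the compounds shown here, a 1.2-fold lower number from compound 3 to compound 4 (0.08 log units; within the scatter) gives the first reading of a single ring stereocentre inverted on its own, and with the chain carbon drawn S this inversion stays within the scatter. The steps of an at least 41-fold lower number from compound 2 to compound 4 (1.61 log units; beyond the scatter) and an at least 41-fold lower number from compound 1 to compound 4 (1.61 log units; beyond the scatter) each invert the chain stereocentre together with one ring stereocentre, and both are large, though each starts from a limit of the assay: the limit of > 12 h in this assay, at which 2 of the 4 values shown sit. Among these four compounds, the two drawn S at the chain carbon now both sit far from the two drawn R, and none goes against this.

From the compounds shown here alone, the step between the two compounds at the limit cannot be read, so what the ring stereocentres do with the chain carbon drawn R stays open. Also open, going by these compounds, is how the shared core behaves with a primary amide in place of the carboxylic acid.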